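Toward compound 3: swapping the methoxypyridine for a chloropyridine

The source may hold more compounds than are shown below. What is called first, only, known or untested is meant among the compounds shown, and "the series" means these compounds.

Compound 1 `COc1ccc(-c2nc3ccccn3c2Nc2ccc(F)cc2)nc1` gives 15400 nM in an ADME assay on THP-1 cells (Homo sapiens) for cytotoxicity; on this read-out higher numbers stand for lower toxicity in this test and lower numbers for higher toxicity in this test.
Compound 2 `COc1ccnc(-c2nc3ccccn3c2Nc2ccc(F)cc2)c1` gives 4220 nM in this assay.

Compound 2 shows the lowest number of the two, the step of a 3.6-fold lower number from compound 1 to compound 2 (0.56 log units; beyond the scatter) separating it from compound 1. Compound 3 `Fc1ccc(Nc2c(-c3ccc(Cl)cn3)nc3ccccn23)cc1` arises from compound 2 by 5-chloropyridin-2-yl in place of 4-methoxypyridin-2-yl on an aromatic carbon. For the measured compounds named here, only that one step, between the two methoxypyridines, bears on this change, and it was modest; it says nothing direct about a chlorine. Compound 3 is therefore expected to land near compound 2, with a small shift toward a higher number, a 1.4-fold higher number from compound 2 to compound 3 (0.15 log units; within the scatter). The estimate for compound 3 in this assay is 6000 nM, within 2000 nM to 18000 nM.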

Compound 3, half-maximal cytotoxic concentration: > 50000 nM
Compound 3 gave a limit, no number; the forecaster's own chance of this, stated with the estimate: 10%; middle value at least 8.3-fold (0.92 log units) away from the limit.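

Compound 3 gives only a limit of the assay, not a number, in this assay: the limit of > 50000 nM in this assay, at which 1 of the 3 values shown sits. Putting 5-chloropyridin-2-yl in place of 4-methoxypyridin-2-yl gives an at least 11-fold higher number from compound 2 to compound 3 (1.07 log units; beyond the scatter), and chloro in place of methoxy gives an at least 3.2-fold higher number from compound 1 to compound 3 (0.51 log units; beyond the scatter). This place on the shared core therefore moves the read-out by more than the two methoxypyridines alone showed, and both steps point to lower toxicity in this test. On these data alone, how far compound 3 lies past its limit stays open. So does whether a fluoro, an amine or a carboxylic acid on that pyridine would behave like the chloro.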